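This account rests on a few compounds, and the source may have more. Where it says the series, first, only, none or still open, it means among the compounds named here.

Measured compounds:
compound 1 `O=C1/C(=C/c2ccncc2)C(c2ccccc2)Oc2ccccc21` — 800 nM
compound 2 `COc1ccc2c(c1)OC(c1ccccc1)/C(=C\c1ccncc1)C2=O` — 620 nM

Within the data shown here, in an assay for binding affinity to Aromatase (Homo sapiens), using microsomes (on this read-out lower numbers stand for stronger inhibition and higher numbers for weaker inhibition), compound 1 gives 800 nM and stands at the highest of the two numbers measured so far; its nearest neighbour is compound 2, and the change a 1.3-fold lower number from compound 1 to compound 2 (0.11 log units; within the scatter) is within the scatter, so the two compounds are not distinguished on this read-out.

Compound 3 `O=C1/C(=C\c2ccncc2)C(c2ccccc2)Oc2ccccc21` is not yet measured. It differs from compound 1 in one respect only: the two compounds have the same atoms and bonds; at least one stereo element is drawn with a configuration in one of them and without one in the other: 1 of 2 stereo elements differ; a double bond is drawn E in compound 1 and Z in compound 3. Nothing leaves and nothing enters; only the geometry of the double bond is drawn differently.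

Among the measured compounds shown here, no measured step bears on this change. For the measured compounds named here, the single step in hand, from compound 1 to compound 2, concerns a methoxy in place of hydrogen on an aromatic carbon and says nothing about the double bond geometry. The size and direction of the step of no change at the digits printed from compound 1 to compound 3 (within the scatter) are therefore expected without support from the series, and the estimate for compound 3 is anchored on compound 1 with a wide range. Compound 3 is expected to give 800 nM in this assay, between 200 nM and 3200 nM.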

Compound 3, half-maximal inhibitory concentration: 3300 nM
For compound 3 the middle estimate is 4.1-fold (0.62 log units) below the measured one; the measured number lies above the stated range.
By their numbers in this assay, from the lowest: compounds 2 and 1 (each within the scatter of the next); then compound 3.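

The double bond geometry is a place in this series where the read-out responds, even though nothing leaves or enters: in this assay the change gives a step beyond the scatter (a 4.1-fold higher number from compound 1 to compound 3 (0.62 log units; beyond the scatter)). Among these compounds, the only earlier step, methoxy in place of hydrogen on an aromatic carbon, stayed within the scatter (a 1.3-fold lower number from compound 1 to compound 2 (0.11 log units; within the scatter)), so the series now holds one change that separates two compounds on this read-out and one that does not. This is a single pair, and reading its step as an effect of geometry rests on how the two structures are drawn: the fact that one of compounds 1 and 3 is drawn with a defined configuration and the other without, at the place where they differ.

The compounds shown leave open whether the geometry step carries over to the methoxy compound 2, and what part the second stereo element, which is the same in compound 1 and compound 3, plays in the read-out. They also leave open how an amine, a carboxylic acid or a longer alkoxy chain would read on the aromatic carbon that carries the methoxy in compound 2, under either double bond geometry.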